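Trimming the Amine Chain: From Propyl to Vinyl

A few compounds are considered here, and "the series" means these few. Any claim that something is new, unique, unknown or untested is made for them only; others in the source may bear on it.

Three compounds share one core and differ only in the chain on the nitrogen attached to the aromatic ring. Compound 1 `CCCCNc1nnc(SCC(=O)N(Cc2cccc([N+](=O)[O-])c2)c2ccc(F)cc2)s1` gives 76% in an assay on isolated protein for inhibition of Amine oxidase [flavin-containing] A (Homo sapiens), read by fluorescence and Amplex Red, with a stated time of 30 min, tested at 10 uM; on this read-out lower numbers stand for a weaker effect and higher numbers for a stronger effect at the one concentration tested. Compound 2 `CC(C)CNc1nnc(SCC(=O)N(Cc2cccc([N+](=O)[O-])c2)c2ccc(F)cc2)s1` gives 72.6% in this assay, and compound 3 `COCCNc1nnc(SCC(=O)N(Cc2cccc([N+](=O)[O-])c2)c2ccc(F)cc2)s1` gives 80.6%. Among these three numbers compound 1 stands second highest, with compound 2 nearest and compound 3 furthest, both within the scatter. The steps measured so far were a number 3.4 percentage points lower from compound 1 to compound 2 (within the scatter), a number 4.6 percentage points higher from compound 1 to compound 3 (within the scatter) and a number 8 percentage points higher from compound 2 to compound 3 (within the scatter); none of them moved the read-out beyond the scatter.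

Compound 4 `C=CCNc1nnc(SCC(=O)N(Cc2cccc([N+](=O)[O-])c2)c2ccc(F)cc2)s1` is not yet measured. It differs from compound 1 as follows: vinyl in place of propyl on a saturated chain carbon bound to a nitrogen on an aromatic ring. This is a change of the same kind as the measured ones, a small alteration of the chain on the ring nitrogen, so a step within the scatter is expected in this assay, with no clear direction. Compound 4 is therefore expected to give about 75%, with a likely range from 62% to 86%. The expected step is a number 1 percentage points lower from compound 1 to compound 4 (within the scatter).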

Compound 4, a percentage reported as inhibition, at one concentration (the size of the read-out at that concentration, not a potency): 75.2%
Beside the measured number, compound 4's estimate is 0.2 percentage points below it, within the range that was stated.
By their numbers in this assay, from the lowest: compounds 2, 4, 1 and 3 (each within the scatter of the next).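

Replacing propyl with vinyl shortens the group from 3 heavy atoms to 2 and adds a double bond outside aromatic rings, yet it gives a number 0.8 percentage points lower from compound 1 to compound 4 (within the scatter) in this assay. Set against the other two chains, vinyl gives a number 5.4 percentage points lower from compound 3 to compound 4 (within the scatter) and a number 2.6 percentage points higher from compound 2 to compound 4 (within the scatter), so a double bond at this place on the chain joins the branched and methoxy variants in reading alike within the scatter. No separate measurement is available to explain why these four chains read so closely.

The compounds shown leave open whether a much longer chain such as octyl, or a chain ending in a carboxylic acid or an amine, would move the number beyond the scatter. With only one concentration tested, they also leave open whether these four compounds would differ in potency.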